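The compounds below may be only part of what the source reports. "The series", "measured", "known", "first", "only" and "open" are said of these compounds alone.

In a functional assay on PC-3 cells (Homo sapiens) for inhibition, read by MTT assay, with a stated time of 48 h (on this read-out higher numbers stand for weaker inhibition and lower numbers for stronger inhibition), the measured compounds stand as follows:

compound 1, `C=C1CC[C@@H]2[C@](C)(CO)[C@H](O)CC[C@@]2(C)[C@@H]1CC(Sc1ccccn1)C1=CCOC1=O`: 18000 nM
compound 2, `C=C1CC[C@@H]2[C@](C)(CO)[C@H](O)CC[C@@]2(C)[C@@H]1CC(Sc1ncccn1)C1=CCOC1=O`: 7000 nM
compound 3, `C=C1CC[C@@H]2[C@](C)(CO)[C@H](O)CC[C@@]2(C)[C@@H]1C/C=C1/C(=O)OCC1OC(=O)CSc1ccc(F)cc1`: 13000 nM

Compound 3 holds the second highest of these three numbers, but its gap to compound 1 and its gap to compound 2 both lie within the usual scatter of this assay, so no order among the three can be read from them. Among the measured compounds shown here, the one step that does exceed the scatter, a 2.6-fold lower number from compound 1 to compound 2 (0.41 log units; beyond the scatter), concerns the swap of one heteroaryl group on a sulfur and has no bearing on the change toward compound 4. Compound 4, `C=C1CC[C@@H]2[C@](C)(CO)[C@H](O)CC[C@@]2(C)[C@@H]1C/C=C1/C(=O)OC[C@H]1OC(=O)CSc1ccc(F)cc1`, differs from compound 3 only in this: the two compounds have the same atoms and bonds; at least one stereo element is drawn with a configuration in one of them and without one in the other: 1 of 7 stereo elements differ; a stereocentre at a saturated ring carbon is drawn without a configuration in compound 3 and S in compound 4. For the measured compounds named here, no measured pair shows what defining that stereocentre at a saturated ring carbon does, so the step expected here is a 1.3-fold lower number from compound 3 to compound 4 (0.11 log units; within the scatter), which would stay within the scatter in either direction. Compound 4 is therefore estimated at 10000 nM, with a range from 4000 nM to 30000 nM.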

Compound 4, half-maximal inhibitory concentration: 14000 nM
Compound 4: the middle estimate sits 1.4-fold (0.15 log units) below what was measured; the range from low to high includes it.
By their numbers in this assay, from the lowest: compounds 2, 3, 4 and 1 (each within the scatter of the next, the first and the last beyond it).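

Within this assay, the stereocentre at the saturated ring carbon is drawn as S in compound 4, and the pair shows a 1.1-fold higher number from compound 3 to compound 4 (0.03 log units; within the scatter), so drawing this configuration does not separate the two compounds on this read-out. Among the compounds shown here, this is the first measured pair to bear on that stereocentre, since the earlier step concerned only the heteroaryl group on a sulfur. The comparison can go no further than what distinguishes the pair: the fact that one of compounds 3 and 4 is drawn with a defined configuration and the other without, at the place where they differ

The compounds shown leave open what the R configuration at this carbon would give, and whether compound 3 holds one stereoisomer or both. They also leave open whether an amine in place of the aryl group on the sulfur of compound 4 would move the number beyond the scatter.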